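Methoxy to methylsulfonyl: expected outcome for compound 3

This account rests on a few compounds, and the source may have more. Where it says the series, first, only, none or still open, it means among the compounds named here.

Compound 2 `COc1ccc(-c2csc(N3N=C(c4ccc(N5CCCCC5)cc4)CC3c3ccc(Cl)cc3)n2)cc1` is held only at a limit: in a functional assay on A-375 cells (Homo sapiens) for antiproliferative activity, read by MTT assay, with a stated time of 72 h (on this read-out lower numbers stand for stronger inhibition and higher numbers for weaker inhibition), compound 2 gives > 100000 nM, a limit of the assay and not a number. Compound 1 `Clc1ccc(-c2csc(N3N=C(c4ccc(N5CCCCC5)cc4)CC3c3ccc(Cl)cc3)n2)cc1` likewise sits at a limit, giving > 100000 nM in this assay. The step that the two limits leave unreadable from compound 1 to compound 2 cannot be read, since both values sit at the limit of > 100000 nM in this assay, at which 2 of the 2 values shown sit. Compound 3 `CS(=O)(=O)c1ccc(-c2csc(N3N=C(c4ccc(N5CCCCC5)cc4)CC3c3ccc(Cl)cc3)n2)cc1` differs from compound 2 by methylsulfonyl in place of methoxy on an aromatic carbon. Going by the values given here, no measured step has a readable size bearing on this change, so no direction beyond the scatter follows from the series. Compound 3 is expected to remain at the limit, with an estimated 100000 nM (range 30000 nM to 300000 nM). The implied step a number no higher from compound 2 to compound 3 (the limit leaves the size open) is an expectation only.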

Compound 3, half-maximal inhibitory concentration: > 100000 nM
Compound 3: no number, only a limit (the forecaster's own chance of this, stated with the estimate: 80%); the middle value lies on the limit itself.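

No step among compound 1, compound 2 and compound 3 can be read, since all three values are limits and not numbers: the limit of > 100000 nM in this assay, at which 3 of the 3 values shown sit.

As far as these compounds go, whether chloro, methoxy and methylsulfonyl on this aromatic carbon differ in their effect at all remains open.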